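The source may hold more compounds than are shown below. What is called first, only, known or untested is meant among the compounds shown, and "the series" means these compounds.

Three compounds share one core and differ only in the group on a saturated chain carbon bound to a carbonyl carbon. Compound 1 `CC(C)[C@H](NC(=O)COc1cccc2ccccc12)C(=O)N[C@@H](CC(=O)O)C(=O)COc1cc(C(F)(F)F)n(C)n1` gives 46000 nM in a functional assay on Jurkat cells (Homo sapiens) for inhibition; a higher number here means a weaker inhibitor, a lower number a stronger inhibitor. Compound 2 `CC(C)[C@H](NC(=O)COc1cccc2ccccc12)C(=O)N[C@@H](CC(=O)O)C(=O)CSc1nc(-c2ccccc2)no1` gives 102000 nM in this assay, and compound 3 `Cc1nnc(SCC(=O)[C@H](CC(=O)O)NC(=O)[C@@H](NC(=O)COc2cccc3ccccc23)C(C)C)s1` gives 190000 nM. Compound 2 thus stands second highest of the three numbers: the step of a 1.9-fold higher number from compound 2 to compound 3 (0.27 log units; within the scatter) lies within the scatter, while a 2.2-fold higher number from compound 1 to compound 2 (0.35 log units; beyond the scatter) lies beyond it. Compound 4 `CC(C)[C@H](NC(=O)COc1cccc2ccccc12)C(=O)N[C@@H](CC(=O)O)C(=O)COn1nnc2ccccc21` has not been measured. It differs from compound 2 in one place: a group of 10 heavy atoms (6 carbon, 3 nitrogen, 1 oxygen; one five-membered aromatic ring with 3 hetero atoms, one six-membered aromatic ring of carbon only) in place of a group of 12 heavy atoms (8 carbon, 2 nitrogen, 1 oxygen, 1 sulfur; one five-membered aromatic ring with 3 hetero atoms, one six-membered aromatic ring of carbon only), on a saturated chain carbon bound to a carbonyl carbon. The measured steps that bear on this swap are a 2.2-fold higher number from compound 1 to compound 2 (0.35 log units; beyond the scatter) and a 4.1-fold higher number from compound 1 to compound 3 (0.62 log units; beyond the scatter); in both, the group joined through oxygen went with the lowest number and a group joined through sulfur with a higher one. Among the compounds with values here, compound 4 again carries a group joined through oxygen, and no measured pair is this exact swap. For compound 4 a modest step toward a lower number is expected, a 1.7-fold lower number from compound 2 to compound 4 (0.23 log units; within the scatter). Compound 4 is therefore estimated at 60000 nM, between 20000 nM and 200000 nM.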

Compound 4, half-maximal inhibitory concentration: > 200000 nM
Compound 4 ended at the assay's limit (the forecaster's own chance of this, stated with the estimate: 15%); middle value at least 3.3-fold (0.52 log units) from the limit.
By their numbers in this assay, from the lowest: compound 1; then compounds 2 and 3 (each within the scatter of the next). At a limit, above all of these: compound 4.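

In this assay compound 4 ended at a limit and not at a number: the limit of > 200000 nM in this assay, at which 1 of the 4 values shown sits. Compound 1 and compound 4 both carry a group joined through oxygen, yet the data show an at least 4.3-fold higher number from compound 1 to compound 4 (0.63 log units; beyond the scatter), so at this saturated chain carbon an oxygen link alone does not go with a low number. As far as these compounds go, the steps of an at least 1.9-fold higher number from compound 2 to compound 4 (0.29 log units; that floor lies within the scatter) and an at least 1.0-fold higher number from compound 3 to compound 4 (0.02 log units; that floor lies within the scatter) give only floors within the scatter, so how far compound 4 lies from the two groups joined through sulfur stays unknown.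

No pair shown carries the same ring joined once through oxygen and once through sulfur, so the effect of the link cannot be separated from that of the ring. From the compounds shown here alone, what an amine or a plain phenoxy group would give at this carbon also remains open.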